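From compound 1 to its bromo analogue, compound 4

The source may report more compounds than this note shows. Statements on the series, on what has been measured and on what is new or still open speak of the compounds shown alone.

compound 1 `Cn1c(-c2ccccc2)cnc1NC(=O)c1ccc(F)cc1`: > 100000 nM
compound 2 `Cc1ccccc1C(=O)Nc1ncc(-c2ccccc2)n1C`: > 100000 nM
compound 3 `COc1ccc(-c2cn(C)c(NC(=O)c3ccc(F)cc3)n2)cc1`: > 50000 nM

All three compounds were tested in a toxicity assay on THP-1 cells (Homo sapiens) for inhibition (a higher number here means that more compound is tolerated, a lower number that less compound is tolerated), and none of them has yet given an actual number. Compound 1 stands at > 100000 nM, which is a limit of the assay and not a number. Going by these compounds, that places compound 1 at the limit of > 100000 nM in this assay, at which 2 of the 3 values shown sit, so its true position is unknown. Compound 3 also ends at a limit, (the limit of > 50000 nM in this assay, at which 1 of the 3 values shown sits).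

The next compound is compound 4 `Cn1c(-c2ccc(Br)cc2)cnc1NC(=O)c1ccc(F)cc1`, which keeps the core of compound 1 and changes phenyl to 4-bromophenyl: bromo in place of hydrogen on an aromatic carbon. Going by the values given here, only one measured step is available, a step that the two limits leave unreadable from compound 1 to compound 2, with 2-methylphenyl in place of 4-fluorophenyl on a carbonyl carbon. That step concerns a different group and has no readable size, so it offers nothing to carry over to the bromo change. Among the compounds with values here, compound 3 offers no measured step from compound 1 either.

The expectation is therefore no clear step in this assay, leaning if anything toward a lower number, and another limit would be no surprise. The expected step is an at least 1.2-fold lower number from compound 1 to compound 4 (0.09 log units; that floor lies within the scatter). For compound 4 the estimated value is 80000 nM. The expected range for compound 4 runs from 30000 nM to 150000 nM.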

Compound 4, half-maximal cytotoxic concentration: 46000 nM
Estimate against measurement, compound 4: 1.7-fold (0.24 log units) above; measured number inside the range.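

Compound 4 gives the first actual number among the compounds shown in this assay: compound 4 reaches 46000 nM. The earlier compounds shown here end only at limits. Bromo in place of hydrogen, on an aromatic carbon para to a large group, therefore gives the first change with a readable direction, an at least 2.1-fold lower number from compound 1 to compound 4 (0.33 log units; beyond the scatter), and the other step shown cannot be read. This size is only a floor, as the value of compound 1 is a limit and not a number: the limit of > 100000 nM in this assay, at which 2 of the 4 values shown sit.

The compounds shown leave open how far the true value of compound 1 lies from that of compound 4, and so how large the step really is. They also leave open whether the lower number belongs to bromo itself or would also follow from chloro, an amine or a carboxylic acid at the same place, and whether it would hold with the 2-methylphenyl group of compound 2 on the carbonyl carbon.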